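This account rests on a few compounds, and the source may have more. Where it says the series, first, only, none or still open, it means among the compounds named here.

Among the measured compounds shown here, in a functional assay on V79 cells (Cricetulus griseus) for cytotoxicity, read by colony formation (on this read-out lower numbers stand for stronger inhibition and higher numbers for weaker inhibition), compound 2 `Nc1c(F)c(N2CCC(N)C2)c(F)c2c1c(=O)c(C(=O)O)cn2C1CC1` gives 15 ug/mL, the only single number it has, while a further entry offers none. Compound 1 `COc1c(N2CCC(N)C2)c(F)cc2c(=O)c(C(=O)O)cn(C3CC3)c12` repeats closely: the several entries of compound 1 in this assay, 45 ug/mL; 44 ug/mL; 45 ug/mL (3 entries). Compound 3 `COc1c(N2CCC(N)C2)c(F)c(N)c2c(=O)c(C(=O)O)cn(C3CC3)c12` has methoxy in place of fluoro on an aromatic carbon of compound 2 (methoxy in place of fluoro on an aromatic carbon). For the measured compounds named here, no measured step isolates this change. Going by the values given here, the only guide is that compound 1, which also carries methoxy, gives 45 ug/mL; 44 ug/mL; 45 ug/mL (3 entries), a higher number than compound 2 shows, so a moderate move toward weaker inhibition is expected. The estimate amounts to a 2.0-fold higher number from compound 2 to compound 3 (0.30 log units; within the scatter), an expected rise. Compound 3 is estimated at 30 ug/mL, within 13 ug/mL to 65 ug/mL.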

Compound 3, half-maximal inhibitory concentration: 100 ug/mL
Compound 3: the middle estimate sits 3.3-fold (0.52 log units) below what was measured, and the stated range ends below it.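

Replacing fluoro with methoxy on this aromatic carbon, ortho to the 3-aminopyrrolidin-1-yl group and para to the amino group, now has a direct measure: in this assay it gives a 6.7-fold higher number from compound 2 to compound 3 (0.82 log units; beyond the scatter), a clear weakening of inhibition. This gap can be trusted as more than repeat noise because readings of a single compound here agree closely: the several entries of compound 1 in this assay, 45 ug/mL; 44 ug/mL; 45 ug/mL (3 entries).

This one step cannot separate the effect of the methoxy oxygen from that of its carbon. Going by these compounds, how a hydroxyl group or a longer ethoxy chain would behave on this carbon remains open.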